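Exchanging a Hydroxycyclohexyl Ring for an Oxane Ring

The source may hold more compounds than are shown below. What is called first, only, known or untested is meant among the compounds shown, and "the series" means these compounds.

Measured compounds:
Compound 1 `N#Cc1cnc(NCc2ccccc2C(F)(F)F)cc1N[C@H]1CC[C@H](O)CC1` — 4000 nM
Compound 2 `CO[C@H]1CC[C@@H](Nc2cc(NCc3cnccc3C(F)(F)F)ncc2C#N)CC1` — 58 nM
Compound 3 `N#Cc1cnc(NCc2cnccc2C(F)(F)F)cc1NC[C@H]1CC[C@@H](O)CC1` — 58 nM

In an assay on isolated protein for inhibition of protein kinase C theta type (Homo sapiens), read by TR-FRET, with a stated time of 2 h (on this read-out higher numbers stand for weaker inhibition and lower numbers for stronger inhibition), compound 3 gives 58 nM, level with compound 2 and with a far lower number than compound 1. Compound 4 `N#Cc1cnc(NCc2cnccc2C(F)(F)F)cc1NCC1CCOCC1` differs from compound 3 in one place: oxan-4-yl in place of 4-hydroxycyclohexyl on a saturated chain carbon bound to a nitrogen on an aromatic ring. The hydroxyl, the only hydrogen-bond donor in that ring, leaves; an oxygen acceptor remains within the ring. Among the compounds with values here, the one measured step touching this region, no change at the digits printed from compound 2 to compound 3 (within the scatter), reshaped the saturated ring portion without any shift, so the region appears tolerant of such changes. Compound 4 is therefore expected to stay close to compound 3, with a step of a 1.4-fold higher number from compound 3 to compound 4 (0.14 log units; within the scatter) estimated. The estimate for compound 4 is 80 nM, expected between 30 nM and 250 nM.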

Compound 4, half-maximal inhibitory concentration: 400 nM
Compound 4: middle estimate off by 5.0-fold (0.70 log units), on the low side, and the stated range ends below it.
By their numbers in this assay, from the lowest: compounds 2 and 3 (each within the scatter of the next); then compound 4; then compound 1.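

In this assay, this position proves less tolerant than the earlier flat step suggested: oxan-4-yl in place of 4-hydroxycyclohexyl gives a 6.9-fold higher number from compound 3 to compound 4 (0.84 log units; beyond the scatter). (Oxan-4-yl)methyl in place of 4-methoxycyclohexyl gives the same size of change, a 6.9-fold higher number from compound 2 to compound 4 (0.84 log units; beyond the scatter), so the two earlier ring variants stay level while this one falls behind both. No evidence at hand accounts for this loss. The change removes the hydroxyl and brings an oxygen into the ring together, and the compounds shown leave open which of the two carries the step. A plain cyclohexylmethyl or a (4-aminocyclohexyl)methyl in the same place would help to separate them.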